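A few compounds are considered here, and "the series" means these few. Any claim that something is new, unique, unknown or untested is made for them only; others in the source may bear on it.

Compound 1 `COc1ccc(C(=O)/C=C/c2cccc(F)c2)c2c1C=CC(C)(C)O2` carries a 3-fluorophenyl group on the shared core. In a functional assay on SW-620 cells (Homo sapiens) for antiproliferative activity, read by MTT assay, with a stated time of 24 h (on this read-out higher numbers stand for weaker inhibition and lower numbers for stronger inhibition), compound 1 gives > 10000 nM, which is a limit of the assay and not a number. Compound 1 therefore stands at the limit of > 10000 nM in this assay, at which 1 of the 2 values shown sits, so only a boundary is known for it. The second measured compound, compound 2 `COc1ccc(C(=O)/C=C/c2ccc3ccccc3n2)c2c1C=CC(C)(C)O2`, replaces the aromatic ring with a different one and in this assay gives 2250 nM. Going by the values given here, no step between compound 1 and compound 2 is worked out here, so the two values are only set side by side and nothing further is drawn from them.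

The compound not yet measured is compound 3 `COc1ccc(C(=O)/C=C/c2ccccc2)c2c1C=CC(C)(C)O2`. It differs from compound 1 by hydrogen in place of fluoro on an aromatic carbon. Among the compounds with values here, no measured pair of this kind is available, so the expectation rests on compound 1 alone. Since compound 1 already sits at the limit of this assay, the change is expected to move little, and the step that the limit leaves unreadable from compound 1 to compound 3 is estimated to stay within the scatter. Compound 3 is accordingly expected to give about 15000 nM in this assay, with a range from 5000 nM to 50000 nM.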

Compound 3, half-maximal inhibitory concentration: > 10000 nM
Compound 3: no number, only a limit (the forecaster's own chance of this, stated with the estimate: 70%); the middle value does not contradict the limit.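

Compound 1 and compound 3 each give only a limit and not a number in this assay, so no step between compound 1 and compound 3 can be read: the limit of > 10000 nM in this assay, at which 2 of the 3 values shown sit.

The compounds shown leave open whether hydrogen in place of fluoro on an aromatic carbon changes antiproliferative activity at all, and by how much.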